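The compounds below may be only part of what the source reports. "The series", "measured", "known", "first", "only" and "open" are said of these compounds alone.

Among the compounds with values here, in a physicochemical assay for solubility, measured as kinetic solubility, with a stated time of 15 h, at pH 7.4 (a lower number here means a less soluble compound, a higher number a more soluble compound), compound 3 `O=[N+]([O-])c1cccc(-c2ccc(O[C@H]3O[C@H](CO)[C@@H](O)[C@H](O)[C@@H]3O)c(Cl)c2)c1` gives 23 ug/mL, the middle of three numbers so far. Compound 1 `O=[N+]([O-])c1ccc(-c2ccc(O[C@H]3O[C@H](CO)[C@@H](O)[C@H](O)[C@@H]3O)c(Cl)c2)cc1` stands highest at 117 ug/mL, and compound 2 `OC[C@H]1O[C@H](Oc2ccc(-c3ccccc3)cc2Cl)[C@@H](O)[C@@H](O)[C@@H]1O` lowest at 5.5 ug/mL. The step to compound 4 `CC(=O)c1ccc(-c2ccc(O[C@H]3O[C@H](CO)[C@@H](O)[C@H](O)[C@@H]3O)c(Cl)c2)cc1` is 4-acetylphenyl in place of 3-nitrophenyl on an aromatic carbon. Within the data shown here, the closest precedent is a 5.1-fold lower number from compound 1 to compound 3 (0.71 log units; beyond the scatter), a modest step between 4-nitrophenyl and 3-nitrophenyl. Removing or restoring nitro gives a 21-fold lower number from compound 1 to compound 2 (1.33 log units; beyond the scatter), which is large, and a 4.2-fold higher number from compound 2 to compound 3 (0.62 log units; beyond the scatter), which is modest. Among the measured compounds shown here, no acetyl compound has been measured, so a modest rise in this assay is expected, on the precedent of compound 1 at 117 ug/mL. The expected step is a 2.2-fold higher number from compound 3 to compound 4 (0.34 log units; beyond the scatter). For compound 4 the estimate is 50 ug/mL, with an expected range of 14 ug/mL to 150 ug/mL.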

Compound 4, solubility: 16 ug/mL
For compound 4 the middle estimate is 3.1-fold (0.49 log units) above the measured one, and the stated range covers the measured number.
By their numbers in this assay, from the lowest: compound 2; then compounds 4 and 3 (each within the scatter of the next); then compound 1.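

In this assay, 4-acetylphenyl and 3-nitrophenyl are not separated at this position, with a 1.4-fold lower number from compound 3 to compound 4 (0.16 log units; within the scatter), so the two groups give numbers within the scatter. Acetyl in place of hydrogen gives a 2.9-fold higher number from compound 2 to compound 4 (0.46 log units; beyond the scatter), while acetyl in place of nitro gives a 7.3-fold lower number from compound 1 to compound 4 (0.86 log units; beyond the scatter), so a group other than nitro also stands clear of the unsubstituted compound 2, yet the high number of compound 1 is not matched. Nothing measured here explains the gap between acetyl and nitro. Going by these compounds, whether an amine or a carboxylic acid in place of nitro would reach the number of compound 1 remains open.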